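Reversing the aryl swap at the ring nitrogen: compound 3

The compounds below may be only part of what the source reports. "The series", "measured", "known", "first", "only" and "open" are said of these compounds alone.

Compound 1 `CC(C)OC(=O)N1CCC(Oc2ncnc3c2CCN3c2ccc(C#N)cc2F)CC1` gives 63.1 nM in a functional assay on CHO-K1 cells for agonist activity at Glucose-dependent insulinotropic receptor (Homo sapiens), read by a luciferase reporter, with a stated time of 5 h; a higher number here means that more compound is needed for the effect, a lower number that less compound is needed.
Compound 2 `Cc1ncccc1N1CCc2c(OC3CCN(C(=O)OC(C)C)CC3)ncnc21` reaches only the limit of > 10000 nM in this assay.

Compound 2 thus stands at the limit of this assay, as the limit of > 10000 nM in this assay, at which 1 of the 2 values shown sits, records, and its potency is known only as a bound. Compound 3 `CC(C)OC(=O)N1CCC(Oc2ncnc3c2CCN3c2ccc(S(C)(=O)=O)c(F)c2)CC1` differs from it by 3-fluoro-4-(methylsulfonyl)phenyl in place of 2-methylpyridin-3-yl on a nitrogen on an aromatic ring in a ring. Among the compounds with values here, the single measured step at this nitrogen, an at least 150-fold higher number from compound 1 to compound 2 (2.19 log units; beyond the scatter), shows how much was lost when 4-cyano-2-fluorophenyl gave way to 2-methylpyridin-3-yl. Compound 3 returns to a phenyl bearing a fluorine and a methylsulfonyl, closer in kind to compound 1 than to compound 2, so a large step downward in this assay is expected, an at least 66-fold lower number from compound 2 to compound 3 (1.82 log units; beyond the scatter). Compound 3 is therefore estimated at 150 nM, within a range of 40 nM to 1000 nM, the width reflecting that compound 2 is known only as a limit.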

Compound 3, half-maximal effective concentration: 158 nM
Compound 3: middle estimate off by 1.1-fold (0.02 log units), on the low side, within the range that was stated.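

Placing 3-fluoro-4-(methylsulfonyl)phenyl in place of 2-methylpyridin-3-yl on this nitrogen gives an at least 63-fold lower number from compound 2 to compound 3 (1.80 log units; beyond the scatter), so activity in this assay does not rest on the 4-cyano-2-fluorophenyl group alone. A phenyl carrying methylsulfonyl and no nitrile holds most of that activity but does not fully match it, with a 2.5-fold higher number from compound 1 to compound 3 (0.40 log units; beyond the scatter). Compound 2 is a limit and not a number, so the size of the recovery is only a bound: the limit of > 10000 nM in this assay, at which 1 of the 3 values shown sits.

The compounds shown do not separate the ring nitrogen of 2-methylpyridin-3-yl from its methyl as the source of the loss, nor the fluorine from the methylsulfonyl as the source of the recovery. From the compounds shown here alone, how a sulfonamide or a carboxamide in place of the methylsulfonyl would read in this assay also stays open.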